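A few compounds are considered here, and "the series" means these few. Any claim that something is new, unique, unknown or untested is made for them only; others in the source may bear on it.

Working notes on the series.

For the measured compounds named here, compound 1 `O=C(O)CC/C=C\CC1COC(c2ccc3ccccc3c2)OC1c1cccnc1` is the first reference point. In an assay for inhibition of Thromboxane-A synthase (Homo sapiens), using microsomes (on this read-out lower numbers stand for stronger inhibition and higher numbers for weaker inhibition), compound 1 gives 50 nM. Compound 2 `CC(C)(Oc1ccccc1F)C1OCC(C/C=C\CCC(=O)O)C(c2cccnc2)O1` carries the same core with a different group on the saturated chain carbon bound to two saturated chain carbons and a saturated ring carbon. In this assay compound 2 gives 45 nM. The two numbers for compound 2 and compound 1 lie within the scatter of each other, so neither compound is separated from the other on this read-out.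

Compound 3 `Cc1ccc(SC(C)(C)C2OCC(C/C=C\CCC(=O)O)C(c3cccnc3)O2)c([N+](=O)[O-])c1` is not yet measured. Relative to compound 2 the change is a group of 11 heavy atoms (7 carbon, 1 nitrogen, 2 oxygen, 1 sulfur; one six-membered aromatic ring of carbon only) in place of a group of 8 heavy atoms (6 carbon, 1 oxygen, 1 fluorine; one six-membered aromatic ring of carbon only), on a saturated chain carbon bound to two saturated chain carbons and a saturated ring carbon. Going by the values given here, no measured pair reports a step of this kind, so the expectation rests only on the two values shown. With compound 1 and compound 2 giving numbers within the scatter despite different groups at this position, the expected step from compound 2 to compound 3 is none beyond the scatter a 1.3-fold higher number from compound 2 to compound 3 (0.12 log units; within the scatter). For compound 3 the estimated value in this assay is 60 nM, with a range from 15 nM to 250 nM.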

Compound 3, half-maximal inhibitory concentration: 30 nM
Beside the measured number, compound 3's estimate is 2.0-fold (0.30 log units) above it, within the range that was stated.
By their numbers in this assay, from the lowest: compounds 3, 2 and 1 (each within the scatter of the next).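

On the saturated chain carbon bound to two saturated chain carbons and a saturated ring carbon, the 2-fluorophenoxy group of compound 2 gives way to a group of 11 heavy atoms with 3 hydrogen-bond acceptors, and this assay shows a 1.5-fold lower number from compound 2 to compound 3 (0.18 log units; within the scatter). This position therefore tolerates a larger group carrying sulfur and nitrogen without a step beyond the scatter, which compound 2 alone could not show. Nothing available explains this result.

The sulfur, the nitrogen-containing group and the methyl group all enter together in compound 3, so their separate contributions remain unresolved. From the compounds shown here alone, it also remains open whether a group without an aromatic ring at this carbon, such as an amine or a longer alkyl chain, would give a step beyond the scatter.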